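Working notes: cyclohexyl in place of methylsulfanyl

The source may report more compounds than this note shows. Statements on the series, on what has been measured and on what is new or still open speak of the compounds shown alone.

- compound 1 `CCC(=O)Oc1cccc2ccc(/C=C/c3ccccc3[N+](=O)[O-])nc12` gives 55200 nM
- compound 2 `CSc1ccc(C(=O)/C=C/c2ccc([N+](=O)[O-])o2)cc1` gives 28400 nM

Both compounds were tested in an ADME assay on cells (Astrocyte, Rattus norvegicus, strain Wistar) for inhibition, read by sulforhodamine B assay, with a stated time of 72 h (on this read-out higher numbers stand for lower toxicity in this test and lower numbers for higher toxicity in this test), and lie within the scatter of each other, so compound 2 does not stand apart from compound 1 on these numbers. Compound 3 `O=C(/C=C/c1ccc([N+](=O)[O-])o1)c1ccc(C2CCCCC2)cc1` carries cyclohexyl in place of methylsulfanyl on an aromatic carbon and otherwise keeps the structure of compound 2. Within the data shown here, no measured pair shows a comparable change, so the data offer no direct guide to this step. The expectation therefore rests on compound 2 at 28400 nM as the starting point. The estimated step of a 1.1-fold lower number from compound 2 to compound 3 (0.06 log units; within the scatter) is expected to stay within the scatter, with no firm direction. Compound 3 is expected at 25000 nM (estimated range 9000 nM to 70000 nM).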

Compound 3, half-maximal cytotoxic concentration: 57200 nM
Beside the measured number, compound 3's estimate is 2.3-fold (0.36 log units) below it, and the stated range covers the measured number.
By their numbers in this assay, from the lowest: compounds 2, 1 and 3 (each within the scatter of the next).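

In this assay the series shows a 2.0-fold higher number from compound 2 to compound 3 (0.30 log units; within the scatter) with cyclohexyl in place of methylsulfanyl on an aromatic carbon, para to a large group. Among these compounds, this is the first comparison between compounds that differ in one place, and it shows that this position takes a six-membered non-aromatic ring of carbon only, with a read-out that does not stand apart from that of compound 2. No supporting measurement bears on this result, so the reading rests on the numbers alone.

From the compounds shown here alone, whether an amine, a carboxylic acid or a longer chain at this position would also stay within the scatter of compound 2 remains open. A single step also cannot show which groups here, if any, would move the read-out beyond the scatter.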